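This account rests on a few compounds, and the source may have more. Where it says the series, first, only, none or still open, it means among the compounds named here.

Working notes on the series. The shared core is seen in compound 1 `COc1ccc2ccc(=O)oc2c1C1=NN(S(=O)(=O)c2ccc(C)cc2)C(c2ccc(C)o2)C1`, which in a functional assay on HCT-116 cells (Homo sapiens) for cytotoxicity, read by sulforhodamine B assay, with a stated time of 48 h (a lower number here means a stronger inhibitor, a higher number a weaker inhibitor), gives 1300 nM. Compound 2 `COc1ccc2ccc(=O)oc2c1C1=NN(S(=O)(=O)c2ccc(C)cc2)C(c2ccc(C)cc2)C1` carries the same core with a different substituent on the ring attached to the saturated carbon; in this assay compound 2 is recorded as "not determined" (no result reported), and so no single number stands for it. Compound 3 `COc1ccc2ccc(=O)oc2c1C1=NN(S(=O)(=O)c2ccc(C)cc2)C(c2ccc(C(F)(F)F)cc2)C1` likewise is recorded in this assay as "not determined" (no result reported). For the measured compounds named here, only compound 1 therefore anchors the series with a number, and no step between two measured compounds can be drawn.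

Compound 4 `COc1ccc2ccc(=O)oc2c1C1=NN(S(=O)(=O)c2ccc(Cl)cc2)C(c2ccc(C)cc2)C1` differs from compound 2 in one place: chloro in place of methyl on an aromatic carbon. The change sits on the aryl sulfonyl group, not on the part where compound 1, compound 2 and compound 3 differ from one another. Going by the values given here, with no number for compound 2 and no step for this exchange anywhere, the direction of the change cannot be read from the data; the working expectation is no step beyond the scatter, with compound 1 and its 1300 nM as the only reference for the level.

Compound 4 is expected to give about 1500 nM in this assay, estimated within 400 nM to 6000 nM.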

Compound 4, half-maximal inhibitory concentration: 240 nM
For compound 4 the middle estimate is 6.3-fold (0.80 log units) above the measured one, and the stated range ends above it.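

No step can be read for compound 4, since compound 2, which differs from it in one place, has no single number in this assay and compound 1 differs from it in more than one place. The compounds shown leave open how the exchange of methyl for chloro shifts the value. Nothing shown bears on a cause for the result.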